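A Chloro Group on a Compound at the Assay Limit

The compounds below may be only part of what the source reports. "The series", "measured", "known", "first", "only" and "open" are said of these compounds alone.

In a functional assay on Huh-7 cells (Homo sapiens) for antiproliferative activity, read by sulforhodamine B assay, with a stated time of 72 h (on this read-out lower numbers stand for stronger inhibition and higher numbers for weaker inhibition), compound 1 (`CSc1ccc(Nc2ncnc3c2ncn3[C@@H]2O[C@H](CO)[C@@H](O)[C@H]2O)cc1`) is reported as "not active" (no number reported). Compound 2 (`OC[C@H]1O[C@@H](n2cnc3c(NCCC4=CCCCC4)ncnc32)[C@H](O)[C@@H]1O`), which carries a (2-(cyclohex-1-en-1-yl)ethyl)amino group, gives > 100000 nM, and this is a limit of the assay rather than a number. Among the measured compounds shown here, compound 2 therefore has no exact position on the scale, and no step between measured compounds is available as a guide. Compound 3 (`OC[C@H]1O[C@@H](n2cnc3c(NCCC4=CCCCC4)nc(Cl)nc32)[C@H](O)[C@@H]1O`) has chloro in place of hydrogen on an aromatic carbon, between two ring nitrogen atoms and meta to the (2-(cyclohex-1-en-1-yl)ethyl)amino group [ chloro in place of hydrogen on an aromatic carbon ]. Little change is expected in this assay, with at most a slight move towards stronger inhibition that may stay within the usual scatter. The expected step is an at least 1.2-fold lower number from compound 2 to compound 3 (0.09 log units; that floor lies within the scatter). Compound 3 is estimated at 80000 nM, with an expected range of 25000 nM to 200000 nM.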

Compound 3, half-maximal inhibitory concentration: 20000 nM
Beside the measured number, compound 3's estimate is 4.0-fold (0.60 log units) above it, outside the stated range (below it).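

In this assay, among the compounds shown here, chloro in place of hydrogen on an aromatic carbon, between two ring nitrogen atoms, gives an at least 5.0-fold lower number from compound 2 to compound 3 (0.69 log units; beyond the scatter), and compound 3 gives 20000 nM, the only exact value among the three compounds. This shows that the position responds to a single chlorine atom, which compound 1 and compound 2 could not show, since neither has an exact number. Compound 2 stands at a limit of the assay, so the true size of the step remains unknown: the limit of > 100000 nM in this assay, at which 1 of the 3 values shown sits.

From the compounds shown here alone, whether a bromo group, an amine or a methoxy group on the same carbon would give a lower or higher number than chloro stays open. Also open, going by these compounds, is whether chloro at this place would have a similar effect with a group other than the (2-(cyclohex-1-en-1-yl)ethyl)amino group.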